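The source may report more compounds than this note shows. Statements on the series, on what has been measured and on what is new or still open speak of the compounds shown alone.

Compound 1 `O=C(Nc1cnc(NCc2c(F)ccc3c2CCO3)n2cnnc12)c1ccccc1`: 3
Compound 2 `CN(c1ccccc1)c1cnc(NCc2c(F)ccc3c2CCO3)n2cnnc12`: 3.6
Compound 3 `CC1(C)CC(=O)N(c2cnc(NCc3c(F)ccc4c3CCO4)n3cnnc23)C1`: 2

In a physicochemical assay for lipophilicity, using the shake flask method, in phosphate buffer, measured as octanol-water partition, with a stated time of 30 min, at pH 7.4 (a lower number here means a more polar compound, a higher number a more lipophilic compound), compound 3 stands lowest of the three: the steps of a number 1.00 log units lower from compound 1 to compound 3 (beyond the scatter) and a number 1.60 log units lower from compound 2 to compound 3 (beyond the scatter) both fall beyond the scatter. Compound 4 `O=C(Nc1cnc(NCc2c(F)ccc3c2CCO3)n2cnnc12)c1cccnc1` differs from compound 3 in that (((pyridin-3-yl)carbonyl)amino in place of 4,4-dimethyl-2-oxopyrrolidin-1-yl on an aromatic carbon). Going by the values given here, the step that bears on this is a number 1.00 log units lower from compound 1 to compound 3 (beyond the scatter), since compound 4 carries the carbonylamino group of compound 1 again, now with pyridin-3-yl on the carbonyl; no measured pair separates that ring from the phenyl of compound 1. The reversal of a number 1.00 log units lower from compound 1 to compound 3 (beyond the scatter) points to a rise in this assay. Compound 1 gives 3 in this assay, and for want of a pyridine comparison the expectation is set somewhat short of that value. Compound 4 is expected at 2.4, between 1.6 and 3.2. For compound 4 this estimate means a number 0.40 log units higher from compound 3 to compound 4 (beyond the scatter).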

Compound 4, distribution coefficient: 2
Estimate against measurement, compound 4: 0.40 log units above, and the stated range covers the measured number.
By their numbers in this assay, from the lowest: compounds 3 and 4 (each within the scatter of the next); then compound 1; then compound 2.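

In this assay, going by these compounds alone, the pyridin-3-yl group gives the first direct comparison with phenyl on this carbonyl carbon, and the swap moves the number beyond the scatter (a number 1.00 log units lower from compound 1 to compound 4 (beyond the scatter)). The carbonylamino link therefore does not by itself return the value of compound 1, and the ((pyridin-3-yl)carbonyl)amino group cannot be told apart from 4,4-dimethyl-2-oxopyrrolidin-1-yl at this position (no change at the digits printed from compound 3 to compound 4 (within the scatter)). Against methyl(phenyl)amino, the new group shows a large step (a number 1.60 log units lower from compound 2 to compound 4 (beyond the scatter)).

As far as these compounds go, whether a cyclohexyl or pyrimidin-5-yl group on the carbonyl would read nearer compound 1 or compound 4 remains open. No other measurement is at hand to explain these steps.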